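The source may report more compounds than this note shows. Statements on the series, on what has been measured and on what is new or still open speak of the compounds shown alone.

In an assay on isolated protein for inhibition of leukotriene B4 receptor 1 (Homo sapiens), tested at 10 uM (a higher number here means more inhibition at the concentration tested (going by the name of the read-out), a lower number less inhibition), three compounds built on one shared core have been measured. Compound 1 `C=CCc1cc(C(C)=O)c(O)cc1OCCCCC#N` gives 92%, compound 2 `C=CCc1cc(C(C)=O)c(O)cc1OCCCCCCCCC#N` gives 86%, and compound 3 `C=CCc1cc(C(C)=O)c(O)cc1OCCCCCC(=O)OC` gives 106%. Compound 3 stands highest of the three: the step of a number 14 percentage points higher from compound 1 to compound 3 (beyond the scatter) and the step of a number 20 percentage points higher from compound 2 to compound 3 (beyond the scatter) both exceed the usual scatter, if only modestly, while the step of a number 6 percentage points lower from compound 1 to compound 2 (within the scatter) stays within it.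

Compound 4 `C=CCc1cc(C(C)=O)c(O)cc1OCCCCCC(=O)NO` differs from compound 3 in a single place: hydroxyamino in place of methoxy on a carbonyl carbon. For the measured compounds named here, no measured step alters this exact group. The steps that come closest, a number 14 percentage points higher from compound 1 to compound 3 (beyond the scatter) and a number 20 percentage points higher from compound 2 to compound 3 (beyond the scatter), both rework the far end of the same chain and were modest in size, and all three measured numbers already sit high in this assay at the tested concentration. A further change at that end of the chain is therefore expected to shift this assay little, so the step of a number 11 percentage points lower from compound 3 to compound 4 (beyond the scatter) is expected to lie near or within the scatter. For compound 4 the estimate is 95%, with a range from 75% to 110%.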

Compound 4, a percentage reported as inhibition, at one concentration (the size of the read-out at that concentration, not a potency): 85%
Compound 4: the middle estimate sits 10 percentage points above what was measured; the range from low to high includes it.
By their numbers in this assay, from the lowest: compounds 4, 2 and 1 (each within the scatter of the next); then compound 3.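

In this assay, exchanging methoxy for hydroxyamino on the carbonyl carbon gives a number 21 percentage points lower from compound 3 to compound 4 (beyond the scatter), so a swap of this small group alone is enough to move the read-out beyond the scatter. For the compounds shown here, the new compound also cannot be told apart from the two nitrile compounds, with a number 1 percentage points lower from compound 2 to compound 4 (within the scatter) and a number 7 percentage points lower from compound 1 to compound 4 (within the scatter), which leaves the methoxycarbonyl end of compound 3 as the only end group here that stands apart. Nothing available explains why this exchange lowers the number.

Still open, on these data alone, is where a carboxylic acid or a simple amide on that carbonyl carbon would fall relative to compound 3 and compound 4. Also open, as far as these compounds go, is how a longer or shorter chain carrying the hydroxycarbamoyl group would read.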